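A few compounds are considered here, and "the series" means these few. Any claim that something is new, unique, unknown or untested is made for them only; others in the source may bear on it.

Measured compounds:
compound 1 `C=CCNC1=CC(=O)c2nc(-c3ccccc3)ccc2C1=O`, 14100 nM
compound 2 `O=C1C(N2CC2)=CC(=O)c2nc(-c3ccc(-c4ccccc4)cc3)ccc21`, 26900 nM

In a functional assay on NCI60 cells (Homo sapiens) for cytotoxicity (a lower number here means a stronger inhibitor of growth, a higher number a weaker inhibitor of growth), compound 1 gives 14100 nM, and compound 2 gives 26900 nM; the two numbers lie within the usual scatter of each other, so neither stands apart. Compound 3 `O=C1C(NCc2ccccc2)=CC(=O)c2nc(-c3ccccc3)ccc21` differs from compound 1 by phenyl in place of vinyl on a saturated chain carbon bound to an amine nitrogen. Within the data shown here, no measured pair shows this change, so its effect is unknown; an expected step of a 1.3-fold lower number from compound 1 to compound 3 (0.11 log units; within the scatter), no larger than the scatter, seems reasonable. Compound 3 is therefore estimated at 11000 nM in this assay, with a range from 3500 nM to 35000 nM.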

Compound 3, concentration for total growth inhibition: 15500 nM
Beside the measured number, compound 3's estimate is 1.4-fold (0.15 log units) below it; the range from low to high includes it.
By their numbers in this assay, from the lowest: compounds 1, 3 and 2 (each within the scatter of the next).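

In this assay, phenyl in place of vinyl on a saturated chain carbon bound to an amine nitrogen gives a 1.1-fold higher number from compound 1 to compound 3 (0.04 log units; within the scatter). This is the first pair shown that differs in one place, and it shows that this position accepts benzylamino in place of allylamino, with its added aromatic ring, with no difference that stands out from the scatter. That reading rests on this single pair. Whether a carboxylic acid, an amine or a longer chain at this place would read the same remains open, and no measurement at hand accounts for the result.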